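Amide aryl swap in the cyclopropane dicarboxamide series

This account rests on a few compounds, and the source may have more. Where it says the series, first, only, none or still open, it means among the compounds named here.

Of the compounds shown here, three have been measured so far. Compound 1 `CN(C)C(=O)c1cc2cnc(Nc3ccc(NC(=O)C4(C(=O)Nc5cccc(Br)c5)CC4)cc3)nc2n1C1CCCC1` gives 92.2% in a functional assay on A549 cells (Homo sapiens) for inhibition, read by CCK-8 assay, with a stated time of 72 h, tested at 10 uM; a lower number here means less inhibition of growth, a higher number more inhibition of growth at the concentration tested. Compound 2 `Cc1cccc(NC(=O)C2(C(=O)Nc3ccc(Nc4ncc5cc(C(=O)N(C)C)n(C6CCCC6)c5n4)cc3)CC2)c1` gives 86.1% in this assay. Compound 3 `COC(=O)c1ccc(NC(=O)C2(C(=O)Nc3ccc(Nc4ncc5cc(C(=O)N(C)C)n(C6CCCC6)c5n4)cc3)CC2)cc1` gives 92% in this assay. On these numbers compound 3 stands second highest of three; its nearest neighbour is compound 1, with a number 0.2 percentage points lower from compound 1 to compound 3 (within the scatter), and its furthest is compound 2, with a number 5.9 percentage points higher from compound 2 to compound 3 (within the scatter), so all three sit within the scatter of one another.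

The next step changes the aryl on the amide-type nitrogen once more: compound 4 `COc1cccc(NC(=O)C2(C(=O)Nc3ccc(Nc4ncc5cc(C(=O)N(C)C)n(C6CCCC6)c5n4)cc3)CC2)c1` carries 3-methoxyphenyl in place of 4-(methoxycarbonyl)phenyl on an amide-type nitrogen. Among the compounds with values here, the steps that bear on this are those already made at the same place. The change from compound 1 to compound 3 at that nitrogen gave a number 0.2 percentage points lower from compound 1 to compound 3 (within the scatter), and the change from compound 2 to compound 3 gave a number 5.9 percentage points higher from compound 2 to compound 3 (within the scatter). Both stay within the scatter, as does a number 6.1 percentage points lower from compound 1 to compound 2 (within the scatter), which alters the same aryl at one carbon. Within the data shown here, no step in this set has yet moved this assay beyond the scatter.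

Accordingly, for compound 4 no step beyond the scatter is expected, with a number 3 percentage points lower from compound 3 to compound 4 (within the scatter). Compound 4 is therefore estimated at 89%, with a range from 79% to 96%.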

Compound 4, percent growth inhibition at one concentration: 96%
Compound 4: middle estimate off by 7 percentage points, on the low side; measured number inside the range.
By their numbers in this assay, from the lowest: compounds 2, 3, 1 and 4 (each within the scatter of the next).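

Notes on the aryl on the amide-type nitrogen: in this assay the exchange of 4-(methoxycarbonyl)phenyl, with 10 heavy atoms and 2 hydrogen-bond acceptors, for 3-methoxyphenyl, with 8 heavy atoms and 1 hydrogen-bond acceptor, gives a number 4 percentage points higher from compound 3 to compound 4 (within the scatter) and so adds a smaller group with a different substituent and substitution position without a step beyond the scatter. On an aromatic carbon, methoxy in place of methyl gives a number 9.9 percentage points higher from compound 2 to compound 4 (within the scatter) and methoxy in place of bromo gives a number 3.8 percentage points higher from compound 1 to compound 4 (within the scatter) as the two single-atom-site comparisons for this new substituent, and the first of these is the widest step in the set so far, though it stays within the scatter, as does every other step among the four compounds. No measurement is available that gives a reason for any of these numbers.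

Still open, from the compounds shown here alone, is whether an aryl carrying an amine or a carboxylic acid, or a cyclohexyl group in place of the aryl, on the amide-type nitrogen would give a step beyond the scatter. With all four compounds within the scatter at a single concentration, the set also leaves open whether these aryl groups would separate in a full concentration-response read-out.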